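Shifting a Single Fluorine Around the Aryl Group

The source may report more compounds than this note shows. Statements on the series, on what has been measured and on what is new or still open speak of the compounds shown alone.

Among the measured compounds shown here, in a functional assay on A549 cells (Homo sapiens) for cytotoxicity, read by MTT assay, with a stated time of 72 h (a higher number here means a weaker inhibitor, a lower number a stronger inhibitor), compound 2 `Cc1cc(=O)n(-c2cccc(F)c2)nc1C(=O)Nc1ccc(Oc2ncnc3sccc23)c(F)c1` gives 19500 nM, one of only two numbers so far and within the scatter of the other, compound 1 `Cc1cc(=O)n(-c2ccc(Br)cc2F)nc1C(=O)Nc1ccc(Oc2ncnc3sccc23)c(F)c1`, which gives 11500 nM. Compound 3 `Cc1cc(=O)n(-c2ccc(F)cc2)nc1C(=O)Nc1ccc(Oc2ncnc3sccc23)c(F)c1` differs from compound 2 by 4-fluorophenyl in place of 3-fluorophenyl on an aromatic nitrogen. For the measured compounds named here, the one measured step touching this position, a 1.7-fold higher number from compound 1 to compound 2 (0.23 log units; within the scatter), also exchanged the aryl group on that aromatic nitrogen and stayed within the scatter, so no step beyond the scatter is expected here either. Compound 3 is therefore estimated at 17000 nM, with a range from 7000 nM to 40000 nM. The implied step, a 1.1-fold lower number from compound 2 to compound 3 (0.06 log units; within the scatter), is expected to remain within the scatter.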

Compound 3, half-maximal inhibitory concentration: 2620 nM
Compound 3: middle estimate off by 6.5-fold (0.81 log units), on the high side; measured number outside the range, below it.
By their numbers in this assay, from the lowest: compound 3; then compounds 1 and 2 (each within the scatter of the next).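

In this assay the same atoms give a 7.4-fold lower number from compound 2 to compound 3 (0.87 log units; beyond the scatter) when the lone fluorine goes from the 3-fluorophenyl to the 4-fluorophenyl arrangement, so this group on the aromatic nitrogen does respond to where one fluorine sits. The 4-fluorophenyl group also separates from the 4-bromo-2-fluorophenyl group, with a 4.4-fold lower number from compound 1 to compound 3 (0.64 log units; beyond the scatter) in the same assay. Nothing measured here explains these differences.

From the compounds shown here alone, whether fluorine itself matters remains open. So does how a plain phenyl, 4-methoxyphenyl or 4-aminophenyl group would compare on that nitrogen.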